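The compounds below may be only part of what the source reports. "The series", "measured", "known", "first", "only" and "open" are said of these compounds alone.

Working notes on the series. Among the measured compounds shown here, compound 1 `Cc1ccc(-c2nc3ccccc3[nH]2)cc1NC(=S)NC(=O)c1ccc2c(c1)OCCO2` is the only member with a number: in a functional assay on MDA-MB-231 cells (Homo sapiens) for inhibition, read by colorimetric assay and crystal violet staining, with a stated time of 72 h (on this read-out lower numbers stand for stronger inhibition and higher numbers for weaker inhibition), compound 1 gives 500 nM. For the measured compounds named here, compound 2 `N#Cc1ccc2[nH]c(-c3cccc(NC(=S)NC(=O)c4ccc5c(c4)OCCO5)c3)nc2c1` stands without a number on this read-out, recorded as "not determined" (no result reported); compound 3 `COc1ccc(C(=O)NC(=O)Nc2cccc(-c3nc4ccccc4[nH]3)c2)cc1OC` is likewise recorded as "not determined" (no result reported), so no step between measured compounds can be drawn here. Compound 4 `O=C(NC(=S)Nc1cccc(-c2nc3ccccc3s2)c1)c1ccc2c(c1)OCCO2` is the untested member; relative to compound 2 it carries 1,3-benzothiazol-2-yl in place of 5-cyano-1H-benzimidazol-2-yl on an aromatic carbon. Going by the values given here, with no step measured, the size of the change in this assay from compound 2 to compound 4 cannot be read from the data; the only anchor is the value of compound 1, and a modest weakening beyond the scatter is expected rather than a large one. Compound 4 is therefore expected to give about 1000 nM, within 300 nM to 4000 nM.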

Compound 4, half-maximal inhibitory concentration: > 10000 nM
Compound 4: only a limit was reported; the forecaster's own chance of this, stated with the estimate: 15%; middle value at least 10-fold (1.00 log units) from the limit.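

No new step can be read from compound 2 to compound 4: compound 2 has no single number, and compound 4 gives only a limit. The compounds shown leave open how 1,3-benzothiazol-2-yl in place of 5-cyano-1H-benzimidazol-2-yl alone changes the result in this assay.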